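Methoxy in place of bromo on the pendant phenyl

A few compounds are considered here, and "the series" means these few. Any claim that something is new, unique, unknown or untested is made for them only; others in the source may bear on it.

Of the compounds shown here, three sharing one core have been measured in a functional assay on A549 cells (Homo sapiens) for antiproliferative activity, read by MTT assay, with a stated time of 72 h; on this read-out higher numbers stand for weaker inhibition and lower numbers for stronger inhibition. Compound 1 `CCNC(=O)c1cc(Oc2ccc(NC(=O)c3cc4cccnc4n(-c4ccccc4)c3=O)cc2)ccn1` gives 160 nM. Compound 2 `CCNC(=O)c1cc(Oc2ccc(NC(=O)c3cc4cccnc4n(-c4ccc(F)cc4)c3=O)cc2)ccn1`, which carries fluoro in place of hydrogen on an aromatic carbon, gives 120 nM, and the step of a 1.3-fold lower number from compound 1 to compound 2 (0.12 log units; within the scatter) lies within the scatter. Compound 3 `CCNC(=O)c1cc(Oc2ccc(NC(=O)c3cc4cccnc4n(-c4ccc(Br)cc4)c3=O)cc2)ccn1` gives 910 nM, the highest number of the three; the steps of a 5.7-fold higher number from compound 1 to compound 3 (0.75 log units; beyond the scatter) and a 7.6-fold higher number from compound 2 to compound 3 (0.88 log units; beyond the scatter) are both beyond the scatter, so bromo at this position weakens inhibition relative to hydrogen or fluoro.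

Compound 4 `CCNC(=O)c1cc(Oc2ccc(NC(=O)c3cc4cccnc4n(-c4ccc(OC)cc4)c3=O)cc2)ccn1` differs from compound 3 by methoxy in place of bromo on an aromatic carbon. Among the measured compounds shown here, no measured step covers methoxy at this position, so only the steps to compound 3 bear on it: hydrogen and fluoro gave lower numbers than bromo, but methoxy has not been tried. A step back toward the numbers of compounds 1 and 2 is plausible but uncertain, so the expected step is a 2.6-fold lower number from compound 3 to compound 4 (0.41 log units; beyond the scatter). For compound 4 the estimate in this assay is 350 nM, with a range from 100 nM to 1200 nM.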

Compound 4, half-maximal inhibitory concentration: 2010 nM
For compound 4 the middle estimate is 5.7-fold (0.76 log units) below the measured one; measured number outside the range, above it.
By their numbers in this assay, from the lowest: compounds 2 and 1 (each within the scatter of the next); then compound 3; then compound 4.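

In this assay the loss seen with bromo proves not to be unique to bromo: putting methoxy in its place gives a 2.2-fold higher number from compound 3 to compound 4 (0.34 log units; beyond the scatter) rather than any recovery. Measured against the two groups with the lowest numbers, the change is much larger, with fluoro to methoxy giving a 17-fold higher number from compound 2 to compound 4 (1.22 log units; beyond the scatter) and hydrogen to methoxy giving a 13-fold higher number from compound 1 to compound 4 (1.10 log units; beyond the scatter) in a clear drop in inhibition, so among these four compounds this place on the phenyl ring keeps its activity only with hydrogen or fluoro. No measurement shown here explains why the groups fall in this order.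

On these data alone, it remains open whether an amine, a hydroxyl group or a chlorine atom at this place would sit with hydrogen and fluoro or with bromo and methoxy. A longer chain, such as ethoxy, would show whether the number keeps rising beyond methoxy.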